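This account rests on a few compounds, and the source may have more. Where it says the series, first, only, none or still open, it means among the compounds named here.

Measured so far:
Compound 1, `C=C[C@@](C)(/C=C/c1ccc(O)cc1)CC/C=C/C(=O)OCc1ccccc1` — a functional assay on Raji cells (Homo sapiens) for cytotoxicity, with a stated time of 72 h; a higher number here means that more compound is needed for the effect, a lower number that less compound is needed: > 26000 nM (a limit of the assay).
Compound 2, `C=C[C@@](C)(/C=C/c1ccc(O)cc1)CC/C=C(C)/C=C/C(=O)OCc1ccccc1` — this assay: > 26000 nM (a limit).
Compound 3, `C=C[C@@](C)(/C=C/c1ccc(O)c(CO)c1)CCC=C(C)C` — this assay: > 26000 nM (a limit).

Compound 3 thus stands with the other two at the limit of > 26000 nM in this assay, at which 3 of the 3 values shown sit, and no number separates any of the three. Compound 4, `C=C[C@@](C)(/C=C/c1ccc(O)c(/C=C/c2ccc(F)cc2)c1)CCC=C(C)C`, differs from compound 3 in one place: 2-(4-fluorophenyl)ethenyl in place of hydroxymethyl on an aromatic carbon. For the measured compounds named here, no measured step between two compounds matches this change, so its size can only be expected. The author expects a step of an at least 1.7-fold lower number from compound 3 to compound 4 (0.23 log units; that floor lies within the scatter), towards less compound being needed, though it may be no larger than the scatter. For compound 4 the estimate in this assay is 15000 nM, within the range 3000 nM to 40000 nM.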

Compound 4, half-maximal effective concentration: > 26000 nM
Compound 4: no number, only a limit; the forecaster's own chance of this, stated with the estimate: 45%; middle value at least 1.7-fold (0.23 log units) from the limit.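

No step can be read from compound 3 to compound 4, as both results in this assay are limits and not numbers: the limit of > 26000 nM in this assay, at which 4 of the 4 values shown sit. The compounds shown leave open whether any of them has a measurable effect in this assay.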